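The compounds below may be only part of what the source reports. "The series", "measured", "known", "first", "only" and "open" are said of these compounds alone.

Compound 1 `COc1cccc(S(=O)(=O)c2cnc3cc(F)ccc3c2-c2cccc(Cl)c2)c1` is one of three compounds examined in an ADME assay on microsomes from liver (Homo sapiens) for metabolic stability, tested at 2.5 uM; a lower number here means slower removal, a higher number faster removal of the compound. Compound 1 gives 2.97 mL/min. Going by the values given here, compound 2 `COc1cccc(S(=O)(=O)c2cnc3cc(F)ccc3c2-c2cccc(F)c2)c1` gives 3.36 mL/min, and the step of a 1.1-fold higher number from compound 1 to compound 2 (0.05 log units; within the scatter) is the only single-point change among the measured compounds. Compound 3 `N#Cc1cccc(S(=O)(=O)c2cnc3c(F)cccc3c2-c2cccc(Cl)c2)c1` gives 1.11 mL/min; it differs from compound 1 in more than one place, so its value can only be set beside that of compound 1, which shows compound 1 standing second highest of the three, with compound 3 the furthest from it.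

Compound 4 `Cc1ccc(S(=O)(=O)c2cnc3cc(F)ccc3c2-c2cccc(Cl)c2)cc1C` is not yet measured. It differs from compound 1 in one place: 3,4-dimethylphenyl in place of 3-methoxyphenyl on a sulfonyl sulfur. Among the compounds with values here, no measured step touches this sulfonyl-attached ring, since the only measured step concerns a fluoro in place of a chloro elsewhere. With nothing to lean on, the expectation for the step from compound 1 to compound 4 is an estimated change of a 1.2-fold higher number from compound 1 to compound 4 (0.07 log units; within the scatter), which is expected to lie within the scatter. Compound 4 is therefore estimated at 3.5 mL/min, with an expected range from 1.8 mL/min to 7 mL/min.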

Compound 4, intrinsic clearance in a liver preparation (reported as CLH), per the amount of preparation that the assay uses: 4.01 mL/min
Compound 4: the middle estimate sits 1.1-fold (0.06 log units) below what was measured; low and high end bracket the measured number.
By their numbers in this assay, from the lowest: compound 3; then compounds 1, 2 and 4 (each within the scatter of the next).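

Going by these compounds alone, this is the first measured change on the ring attached to the sulfonyl sulfur: in this assay, 3,4-dimethylphenyl in place of 3-methoxyphenyl gives a 1.4-fold higher number from compound 1 to compound 4 (0.13 log units; within the scatter). For this one pair, then, a group with a hydrogen-bond acceptor gives way to a group of carbon only, and the two numbers stay within the usual scatter of each other. Nothing measured alongside these compounds offers an explanation for this result.

A single pair cannot show whether the same holds for very different groups on this ring, such as an amine or a carboxylic acid. It also leaves open whether this exchange would give a similar step on the fluoro-bearing compound 2 rather than on the chloro-bearing compound 1.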